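The compounds below may be only part of what the source reports. "The series", "measured", "known", "first", "only" and "open" are said of these compounds alone.

In a functional assay on K562 cells (Homo sapiens), read by MTT assay, with a stated time of 72 h (on this read-out lower numbers stand for stronger inhibition and higher numbers for weaker inhibition), compound 1 `CNc1ncnc2c1c(-c1cccs1)cn2[C@@H]1O[C@H](CO)[C@@H](O)[C@H]1O` carries thiophen-2-yl on the shared core and gives > 20000 nM, which is a limit and not a number. Compound 2 `CNc1ncnc2c1c(-c1cc3ccccc3o1)cn2[C@@H]1O[C@H](CO)[C@@H](O)[C@H]1O` carries 1-benzofuran-2-yl in that place and gives > 20000 nM, again only a limit. Both compounds therefore stand at the limit of > 20000 nM in this assay, at which 2 of the 2 values shown sit, and compound 2 has no measured potency to serve as a starting point.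

Compound 3 `CNc1ncnc2c1c(I)cn2[C@@H]1O[C@H](CO)[C@@H](O)[C@H]1O` changes one place: iodo in place of 1-benzofuran-2-yl on an aromatic carbon. Iodo replaces 1-benzofuran-2-yl on an aromatic carbon of a five-membered aromatic ring with 1 nitrogen. Among the measured compounds shown here, the only measured step, a step that the two limits leave unreadable from compound 1 to compound 2, exchanges one ring-bearing group for another, and it has no readable size to carry over. For the measured compounds named here, no measured compound yet shows what a group without a ring does in this place. Going by the values given here, the data thus fix no size for the step, so the best guess is that compound 3 stays near the limit, with some room for a real number on the stronger side. The estimated change in this assay is an at least 1.3-fold lower number from compound 2 to compound 3 (0.12 log units; that floor lies within the scatter). For compound 3 the expected value is 15000 nM, with an estimated range from 2500 nM to 20000 nM.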

Compound 3, half-maximal inhibitory concentration: > 20000 nM
Compound 3: a limit, no number; the forecaster's own chance of this, stated with the estimate: 65%; at least 1.3-fold (0.12 log units) between middle value and limit.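

Compound 3 is again only a limit, so compounds 1, 2 and 3 give no readable step among them in this assay: the limit of all three is shared, and a limit is not a number. What the compounds shown leave open is how strongly any of them inhibits, and whether any group in this place changes that.

Evidence for the shared position: the limit of > 20000 nM in this assay, at which 3 of the 3 values shown sit.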